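Ring-nitrogen substituent: benzyl replaced by aryl urea

The compounds below may be only part of what the source reports. "The series", "measured", "known", "first", "only" and "open" are said of these compounds alone.

Going by the values given here, compound 3 `NC(=O)c1c(NC(=O)c2ccccc2Cl)sc2c1CCN(Cc1c(Cl)cccc1Cl)C2` gives the lowest number among the three measured members in a functional assay on MKN-74 cells (Homo sapiens) for antiproliferative activity, with a stated time of 24 h (on this read-out lower numbers stand for stronger inhibition and higher numbers for weaker inhibition), at 4740 nM. Compound 1 `NC(=O)c1c(NC(=O)c2ccccc2Cl)sc2c1CCN(Cc1ccccc1F)C2` gives 12900 nM in this assay, and compound 2 `NC(=O)c1c(NC(=O)c2ccccc2Cl)sc2c1CCN(Cc1ccc([N+](=O)[O-])cc1)C2` gives 31500 nM. All measured steps change only the aryl group on the saturated chain carbon bound to the ring nitrogen: a 2.7-fold lower number from compound 1 to compound 3 (0.43 log units; beyond the scatter), a 6.6-fold lower number from compound 2 to compound 3 (0.82 log units; beyond the scatter) and a 2.4-fold higher number from compound 1 to compound 2 (0.39 log units; beyond the scatter). Compound 4 `NC(=O)c1c(NC(=O)c2ccccc2Cl)sc2c1CCN(C(=O)Nc1ccccc1Cl)C2` takes a different kind of step: (2-chlorophenyl)carbamoyl in place of 2,6-dichlorobenzyl on an amine nitrogen in a ring. Among the compounds with values here, no measured step removes the benzyl group itself or puts a carbamoyl group on this nitrogen, so none bears directly on this change; the measured steps show only that the substituent on this ring nitrogen shifts the numbers modestly, within a narrow band. Compound 3 sits at 4740 nM, which is the best anchor available. A modest rise, a 2.5-fold higher number from compound 3 to compound 4 (0.40 log units; beyond the scatter), is therefore expected, with wide uncertainty in both directions. Compound 4 is estimated at 12000 nM in this assay, with a range of 3000 nM to 45000 nM.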

Compound 4, half-maximal inhibitory concentration: 16300 nM
The estimate for compound 4 lay 1.4-fold (0.13 log units) below the measured number, and the stated range covers the measured number.
By their numbers in this assay, from the lowest: compound 3; then compounds 1, 4 and 2 (each within the scatter of the next, the first and the last beyond it).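

The (2-chlorophenyl)carbamoyl group is the only substituent shown on this amine nitrogen that is not a benzyl group, and in this assay it stays level with two of the benzyl members, with a 1.3-fold higher number from compound 1 to compound 4 (0.10 log units; within the scatter) and a 1.9-fold lower number from compound 2 to compound 4 (0.29 log units; within the scatter). Only the 2,6-dichlorobenzyl group stands apart, with a 3.4-fold higher number from compound 3 to compound 4 (0.54 log units; beyond the scatter), so replacing the benzyl group with this carbamoyl group does not take the series outside the range already spanned by the benzyl compounds. No measured evidence accounts for these differences.

Compound 3 and compound 4 differ both in the group attached to the ring nitrogen and in the chlorine count on the aryl ring, so the two changes cannot be separated. A (2,6-dichlorophenyl)carbamoyl group would separate them, and an acetyl group would show what the aryl ring contributes.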